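The source may report more compounds than this note shows. Statements on the series, on what has been measured and on what is new or still open speak of the compounds shown alone.

Measured compounds:
compound 1 `CO[C@@H]1C/C=C(\C)C(=O)N(C)[C@@H](C(C)C)C(=O)N[C@H](Cc2ccccc2)C(=O)N[C@@H](C(C)C)C(=O)O[C@H](c2ccccc2)[C@H](C)/C=C/C=C/1C` — > 100 nM
compound 2 `CO[C@@H]1C/C=C(\C)C(=O)N(C)[C@@H](C(C)C)C(=O)N[C@H](Cc2cc(Cl)c(O)c(Cl)c2)C(=O)N[C@@H](C(C)C)C(=O)O[C@H](c2ccccc2)[C@H](C)/C=C/C=C/1C` — 21.6 nM
compound 3 `CO[C@@H]1C/C=C(\C)C(=O)N(C)[C@@H](C(C)C)C(=O)N[C@H](Cc2cc(Cl)c(O)c(Cl)c2)C(=O)N[C@@H](CC(C)C)C(=O)O[C@H](c2ccccc2)[C@H](C)/C=C/C=C/1C` — > 100 nM

For the measured compounds named here, in a functional assay on A549 cells (Homo sapiens) for antiproliferative activity, read by MTT assay, with a stated time of 72 h (a higher number here means a weaker inhibitor, a lower number a stronger inhibitor), compound 2 gives 21.6 nM, the only finite number among the three. For compound 1 the value > 100 nM is a limit of the assay. For compound 3 the value > 100 nM is likewise a limit. Both measured steps therefore reach the limit of > 100 nM in this assay, at which 2 of the 3 values shown sit, at one end: an at least 4.6-fold lower number from compound 1 to compound 2 (0.66 log units; beyond the scatter), and an at least 4.6-fold higher number from compound 2 to compound 3 (0.66 log units; beyond the scatter). These two steps concern the aryl group on the side chain and the isopropyl on the ring carbon; neither touches the part of the core that changes next.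

Compound 4 `CC/C1=C\C=C\[C@@H](C)[C@@H](c2ccccc2)OC(=O)[C@H](C(C)C)NC(=O)[C@@H](Cc2cc(Cl)c(O)c(Cl)c2)NC(=O)[C@H](C(C)C)N(C)C(=O)/C(C)=C/C[C@H]1OC` differs from compound 2 only in methyl in place of hydrogen on a saturated chain carbon bound to a double-bonded ring carbon. No measured step bears on a change at that position, so there is nothing in the shown data to point either way. The change is expected to stay within the scatter, with a 1.2-fold higher number from compound 2 to compound 4 (0.06 log units; within the scatter) as the estimated step. For compound 4 the estimate in this assay is 25 nM, with the range 8 nM to 80 nM.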

Compound 4, half-maximal inhibitory concentration: 13.1 nM
Estimate against measurement, compound 4: 1.9-fold (0.28 log units) above; low and high end bracket the measured number.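

The change of methyl in place of hydrogen on a saturated chain carbon bound to a double-bonded ring carbon gives, in this assay, a 1.6-fold lower number from compound 2 to compound 4 (0.22 log units; within the scatter). For the compounds shown here, this is the first reading at this position, and it shows that lengthening methyl to ethyl there leaves the two compounds indistinguishable in this measurement. Unlike the change at the aryl group and the change from isopropyl to isobutyl, each of which has a limit at one end, this step joins two finite numbers, so its size can be stated rather than only bounded: the limit of > 100 nM in this assay, at which 2 of the 4 values shown sit.

The compounds shown leave open whether this tolerance extends beyond a single added methyl, for instance to a propyl chain, a hydroxymethyl group or an amine at this position. They also leave open whether ethyl in place of methyl would read the same alongside the phenyl of compound 1 or the isobutyl of compound 3, since the results for those two compounds are limits and give no number to start from.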